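Cyano to fluoro on the acid-bearing ring

This account rests on a few compounds, and the source may have more. Where it says the series, first, only, none or still open, it means among the compounds named here.

Compound 2 `Cc1nn(-c2ccccn2)c2cc(-c3ccc(CCC(=O)O)cc3C#N)ccc12` is one of two members of the series measured in a functional assay on cells for agonist activity at Free fatty acid receptor 1 (Mus musculus), read by FLIPR and calcium flux, with a stated time of 5 min; on this read-out higher numbers stand for an effect only at larger amounts of compound and lower numbers for an effect already at smaller amounts. In this assay, going by the values given here, compound 2 gives 6100 nM, the lowest of the two numbers so far. Among the compounds with values here, its only neighbour is compound 1 `COc1cc(CCC(=O)O)ccc1-c1ccc2c(C)nn(-c3ccccn3)c2c1`, which in this assay gives 8200 nM. Within the data shown here, the single measured step, a 1.3-fold lower number from compound 1 to compound 2 (0.13 log units; within the scatter), came with cyano in place of methoxy on an aromatic carbon, and did not exceed the scatter.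

Compound 3 `Cc1nn(-c2ccccn2)c2cc(-c3ccc(CCC(=O)O)cc3F)ccc12` is not yet measured. It differs from compound 2 in one place: fluoro in place of cyano on an aromatic carbon. Among the measured compounds shown here, the one measured step bears on this change in that it too exchanged the group on this aromatic carbon, and that step was within the scatter. On this basis no step beyond the scatter is expected in this assay, in either direction, though a single prior step is thin support.

Compound 3 is therefore expected near 7000 nM, with a range from 2500 nM to 20000 nM. The expected step is a 1.1-fold higher number from compound 2 to compound 3 (0.06 log units; within the scatter).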

Compound 3, half-maximal effective concentration: 1500 nM
Compound 3: middle estimate off by 4.7-fold (0.67 log units), on the high side, outside the stated range (below it).
By their numbers in this assay, from the lowest: compound 3; then compounds 2 and 1 (each within the scatter of the next).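

At this aromatic carbon, ortho to a large group and meta to a 2-carboxyethyl group, the number in this assay does depend on the substituent: fluoro in place of cyano gives a 4.1-fold lower number from compound 2 to compound 3 (0.61 log units; beyond the scatter) and fluoro in place of methoxy gives a 5.5-fold lower number from compound 1 to compound 3 (0.74 log units; beyond the scatter) on the same shared core. The earlier exchange of methoxy for cyano, a 1.3-fold lower number from compound 1 to compound 2 (0.13 log units; within the scatter), stayed within the scatter and on its own gave no sign that this position could separate compounds at all. Going by these compounds alone, with three groups now read here, compounds 1 and 2 remain within the scatter of each other, and compound 3 alone stands apart from both, so the change to fluoro is the first one at this carbon to move the number beyond the scatter.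

Whether this separation is particular to fluoro stays open, since the series shown holds no chloro, methyl or plain hydrogen at this carbon to place beside the three groups compared here. Nothing at hand accounts for why fluoro parts from cyano and methoxy in this way.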